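This account rests on a few compounds, and the source may have more. Where it says the series, first, only, none or still open, it means among the compounds named here.

In a functional assay on MCF7 cells (Homo sapiens) for cytotoxicity, read by MTT assay, with a stated time of 72 h (a higher number here means a weaker inhibitor of growth, a lower number a stronger inhibitor of growth), three compounds have been measured so far:
compound 1 `CSc1nc(NCCCc2ccccc2)c2ccccc2n1`, 77200 nM;
compound 2 `CSc1nc(NCc2ccccc2)c2ccccc2n1`, 41500 nM;
compound 3 `CSc1nc(NCCCCCO)c2ccccc2n1`, 62000 nM.

Compound 3 sits second highest of the three numbers, with a 1.2-fold lower number from compound 1 to compound 3 (0.10 log units; within the scatter) and a 1.5-fold higher number from compound 2 to compound 3 (0.17 log units; within the scatter), both within the scatter. Compound 4 `CSc1nc(Nc2ccccc2)c2ccccc2n1` differs from compound 3 by phenyl in place of 5-hydroxypentyl on a nitrogen on an aromatic ring. The closest measured analogy is the step from compound 2 to compound 3, a hydroxyalkyl chain for phenyl at the nitrogen side, which stayed within the scatter; the step from compound 1 to compound 3 did likewise. No step beyond the scatter is therefore expected in this assay, at most a drift toward the number of compound 2. Compound 4 is estimated at 45000 nM, within 15000 nM to 130000 nM. That estimate corresponds to a 1.4-fold lower number from compound 3 to compound 4 (0.14 log units; within the scatter), expected to stay within the scatter.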

Compound 4, concentration for 50% growth inhibition: 78400 nM
Beside the measured number, compound 4's estimate is 1.7-fold (0.24 log units) below it, and the stated range covers the measured number.
By their numbers in this assay, from the lowest: compounds 2, 3, 1 and 4 (each within the scatter of the next).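

In this assay, phenyl in place of 5-hydroxypentyl on a nitrogen on an aromatic ring gives a 1.3-fold higher number from compound 3 to compound 4 (0.10 log units; within the scatter). The earlier steps shown here kept a saturated chain on this nitrogen, whereas here the phenyl sits on the nitrogen itself, and the change still stays within the scatter. No evidence is available that bears on this result.

The compounds shown leave open whether any group on this nitrogen can move the number beyond the scatter. A chain ending in an amine or a carboxylic acid would be one such test.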